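Replacing the Nitrogen-Rich Group on the Shared Core

The source may hold more compounds than are shown below. What is called first, only, known or untested is meant among the compounds shown, and "the series" means these compounds.

Measured compounds:
- compound 1, `COc1ccc(-c2nc(N=C(N)N)sc2-c2ccc(OC)cc2)cc1`: 31000 nM
- compound 2, `COc1ccc(-c2nc(CN(C)C)sc2-c2ccc(OC)cc2)cc1`: 96 nM
- compound 3, `CNC(=O)NCc1nc(-c2ccc(OC)cc2)c(-c2ccc(OC)cc2)s1`: 22 nM

The read-out is a functional assay with Oryctolagus cuniculus as the target; on this read-out higher numbers stand for weaker inhibition and lower numbers for stronger inhibition. Among the three measured compounds, compound 1 stands highest: the step of a 320-fold lower number from compound 1 to compound 2 (2.51 log units; beyond the scatter) and the step of a 1400-fold lower number from compound 1 to compound 3 (3.15 log units; beyond the scatter) both run far beyond the scatter, and the step of a 4.4-fold lower number from compound 2 to compound 3 (0.64 log units; beyond the scatter) is modest. Compound 1 is therefore the weakest of the three.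

Compound 4, `COc1ccc(-c2nc(C(=O)N3CCCCC3)sc2-c2ccc(OC)cc2)cc1`, has not yet been measured. It differs from compound 1 in one place: a group of 8 heavy atoms (6 carbon, 1 nitrogen, 1 oxygen; one six-membered non-aromatic ring with 1 hetero atom) in place of a group of 4 heavy atoms (1 carbon, 3 nitrogen; no ring), on an aromatic carbon. The two measured steps from compound 1 bear directly on this change, since both also exchange the same group of 4 heavy atoms (1 carbon, 3 nitrogen; no ring) on the same aromatic carbon for something else, and each gave a large fall in the number. Compound 2 carries no hydrogen-bond donor in its new group and still falls well below compound 1, so a large fall is expected for compound 4 too, though the (piperidin-1-yl)carbonyl group is not the same as either group already tried. The expected step is a 100-fold lower number from compound 1 to compound 4 (2.01 log units; beyond the scatter). Compound 4 is estimated at 300 nM, within a range from 40 nM to 3000 nM.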

Compound 4, half-maximal inhibitory concentration: > 1000 nM
Compound 4: a limit, no number; the forecaster's own chance of this, stated with the estimate: 5%; middle value at least 3.3-fold (0.52 log units) away from the limit.
By their numbers in this assay, from the lowest: compound 3; then compound 2; then compound 1.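

In this assay compound 4 gives > 1000 nM, which is a limit of the assay and not a number, so the step from compound 1 to compound 4 cannot be read, and compound 4 cannot be placed relative to compound 1. The steps that can be read are an at least 10-fold higher number from compound 2 to compound 4 (1.01 log units; beyond the scatter) and an at least 45-fold higher number from compound 3 to compound 4 (1.65 log units; beyond the scatter), and both are large, so on this aromatic carbon, removing the nitrogen-rich group of compound 1 does not by itself bring the number down to the level of compound 2 or compound 3, and the group that enters matters a great deal. What is known about compound 4 on this read-out rests on a single bound: the limit of > 1000 nM in this assay, at which 1 of the 4 values shown sits.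

The compounds shown leave open whether the carbonyl bound directly to the aromatic carbon or the piperidine ring accounts for the gap to compound 2 and compound 3. A (piperidin-1-yl)methyl group, which keeps the ring but has a saturated chain carbon in place of the carbonyl, and a dimethylaminocarbonyl group, which keeps the carbonyl but has no ring, would separate these two parts.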